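The source may hold more compounds than are shown below. What is called first, only, known or untested is meant among the compounds shown, and "the series" means these compounds.

Compound 1, `Cc1occc1-c1nnc(SCC(=O)Nc2ccc(F)c(Cl)c2)n1Cc1ccco1`: in a functional assay on CHO cells for antagonist activity at Orexin/Hypocretin receptor type 1 (Homo sapiens), read by FLIPR and calcium flux (on this read-out higher numbers stand for weaker inhibition and lower numbers for stronger inhibition), compound 1 gives 1000 nM.
Compound 2, `Cc1occc1-c1nnc(SCC(=O)Nc2cccc(F)c2)n1Cc1ccco1`: compound 2 gives > 15800 nM, which is a limit of this assay and not a number.
Compound 3, `COc1ccccc1NC(=O)CSc1nnc(-c2ccoc2C)n1Cc1ccco1`: compound 3 gives > 15800 nM, again a limit of this assay and not a number.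

Compound 3 therefore stands only at a limit on the numbers shown; it sits at the limit described in the limit of > 15800 nM in this assay, at which 2 of the 3 values shown sit, together with compound 2, and the step that the two limits leave unreadable from compound 2 to compound 3 cannot be read. Against compound 1 the step of an at least 15-fold higher number from compound 1 to compound 3 (1.19 log units; beyond the scatter) is large, as is an at least 15-fold higher number from compound 1 to compound 2 (1.19 log units; beyond the scatter).

Compound 4, `Cc1occc1-c1nnc(SCC(=O)NN2CCc3ccccc32)n1Cc1ccco1`, differs from compound 3 by 2,3-dihydro-1H-indol-1-yl in place of 2-methoxyphenyl on an amide-type nitrogen.

The measured steps that bear on this place all lead away from compound 1 to limit values; none starts from compound 3 with a readable number, so the expected size of the step in this assay from compound 3 to compound 4 cannot be set from the data, and a value near or at the limit is the plain expectation. Compound 4 is estimated at 15000 nM, within 3000 nM to 50000 nM, which means an expected step of an at least 1.0-fold lower number from compound 3 to compound 4 (0.02 log units; that floor lies within the scatter).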

Compound 4, inhibition constant: > 15800 nM
Compound 4: a limit, no number; the forecaster's own chance of this, stated with the estimate: 60%; middle value at least 1.0-fold (0.02 log units) from the limit.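

In this assay compound 4 gives > 15800 nM, which is a limit of the assay and not a number. Putting 2,3-dihydro-1H-indol-1-yl in place of 3-chloro-4-fluorophenyl on the amide-type nitrogen gives an at least 15-fold higher number from compound 1 to compound 4 (1.19 log units; beyond the scatter), so this replacement, which is not a substituted phenyl, falls short of compound 1 just as the two phenyl replacements do. The steps among compound 2, compound 3 and compound 4 cannot be read, and these three share a single limit: the limit of > 15800 nM in this assay, at which 3 of the 4 values shown sit.

Going by these compounds, how far each of these three lies past the limit, and so how they rank, stays open. Also open, on these data alone, is whether 3-chlorophenyl or 3,4-dichlorophenyl on the amide-type nitrogen would hold the level of compound 1, at 1000 nM.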